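The compounds below may be only part of what the source reports. "The series", "measured", "known", "first", "only" and "open" are said of these compounds alone.

Of the compounds shown here, three have so far been measured in an ADME assay on the whole organism (serum) for protein binding, with Rattus norvegicus as the target, using equilibrium dialysis. Compound 1 `Cc1ccn(-c2ccc(Cn3cc(C(=O)O)c(=O)c4ccncc43)cc2)n1` gives 98.9%, and compound 2 `O=C(O)c1cn(Cc2ccc(-c3ccccc3)cc2)c2ncccc2c1=O` gives 99.7%. Compound 3 `Nc1cccc(-c2ccc(Cn3cc(C(=O)O)c(=O)c4sccc43)nc2)c1` gives 90.1%, which leaves it with the largest unbound fraction of the three, and its gaps to both others lie beyond the usual scatter.

Compound 4 `Cn1cc(-c2ccc(Cn3cc(C(=O)O)c(=O)c4sccc43)nc2)cn1` differs from compound 3 in one group: 1-methyl-1H-pyrazol-4-yl in place of 3-aminophenyl on an aromatic carbon. For the measured compounds named here, no two measured compounds differ in only one place, so there is no direct precedent for this exchange. Compound 3 at 90.1% is the closest reference, while compound 1 at 98.9% shows that higher binding is common in this small set. A small shift in this assay toward more binding is therefore expected, probably not beyond the scatter. The estimated step is a 1.4-fold lower unbound fraction from compound 3 to compound 4 (0.15 log units; within the scatter). For compound 4 the expected value is 93%, with an estimated range of 85% to 98%.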

Compound 4, plasma protein binding: 90.6%
The estimate for compound 4 lay 1.3-fold (0.13 log units) (unbound fraction) below the measured number; the range from low to high includes it.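

For the compounds shown here, compound 3 and compound 4 form the first pair here that differs in only one place, so they give the first direct reading of a change at this position, on an aromatic carbon two atoms from the ring nitrogen. In this assay, replacing 3-aminophenyl with 1-methyl-1H-pyrazol-4-yl gives a 1.1-fold lower unbound fraction from compound 3 to compound 4 (0.02 log units; within the scatter), so the two compounds cannot be told apart, even though a carbon-only six-membered ring with 1 hydrogen-bond donor gives way to a five-membered ring with 2 hetero atoms and 0 donors. Nothing available bears on the reason for this result.

Going by these compounds, it remains open whether a very different group here, such as a carboxylic acid or morpholine, would shift binding beyond the scatter. It is also unknown whether this same exchange would behave alike on another core.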